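The source may report more compounds than this note shows. Statements on the series, on what has been measured and on what is new or still open speak of the compounds shown alone.

Going by the values given here, compound 1 `CCCCCCCCCCCCn1nnc(C(C(=O)Nc2c(OC)cc(OC)cc2OC)c2ccc(N(C)C)cc2)n1` is tested in an assay on liver for inhibition of sterol O-acyltransferase 1 (Rattus norvegicus), using microsomes (on this read-out higher numbers stand for weaker inhibition and lower numbers for stronger inhibition), where compound 1 gives 659 nM, the only outright number in this set. Compound 2 `CCCCCCCCCCCCn1nnc(C(C(=O)Nc2c(C(C)C)cccc2C(C)C)c2nnn[nH]2)n1` reaches only a limit of the assay, with compound 2 giving > 5000 nM in this assay; the limit of > 5000 nM in this assay, at which 1 of the 2 values shown sits, leaves its strength open. Compound 3 `CCCCCCCCCCCCn1nnc(C(C(=O)Nc2c(OC)cc(OC)cc2OC)c2ccccn2)n1` differs from compound 1 by pyridin-2-yl in place of 4-(dimethylamino)phenyl on a saturated chain carbon bound to an aromatic carbon and a carbonyl carbon. Among the compounds with values here, no measured step of this kind is on record, so the expectation for this change rests on compound 1 alone: a loss in this assay beyond the scatter is expected, the step from a 3.0-fold higher number from compound 1 to compound 3 (0.48 log units; beyond the scatter). Compound 3 is therefore estimated at 2000 nM, between 600 nM and 6000 nM.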

Compound 3, half-maximal inhibitory concentration: 590 nM
Compound 3: the middle estimate sits 3.4-fold (0.53 log units) above what was measured, outside the stated range (below it).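

In this assay, the change gives a 1.1-fold lower number from compound 1 to compound 3 (0.05 log units; within the scatter), so on this saturated chain carbon pyridin-2-yl, with 6 heavy atoms, serves as well as 4-(dimethylamino)phenyl, with 9. The dimethylamino group is therefore not needed to hold this level of inhibition in this pair. Nothing measured here accounts for the two groups sitting level. As far as these compounds go, whether a carboxylic acid or an amine on this carbon would hold the same level stays open. From the compounds shown here alone, compound 2 gives > 5000 nM, a limit of the assay, and it differs from the others in more than one place, so what its limit says about this carbon also stays open.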